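The source may report more compounds than this note shows. Statements on the series, on what has been measured and on what is new or still open speak of the compounds shown alone.

Measured in a functional assay on MDA-MB-435S cells (Homo sapiens) for antiproliferative activity, read by MTT assay, with a stated time of 72 h; on this read-out lower numbers stand for stronger inhibition and higher numbers for weaker inhibition:
- compound 1 `COc1ccc2occ(CSC(=S)N3CCCCC3)c(=O)c2c1` gives 930 nM
- compound 2 `COc1ccc2occ(CSC(=S)N3CCCC3)c(=O)c2c1` gives 1800 nM
- compound 3 `COc1ccc2occ(CSC(=S)N(C(C)C)C(C)C)c(=O)c2c1` gives 1800 nM

Compound 2 stands level with compound 3 at the digits reported, the two of them sharing the highest numbers of the three; the nearest neighbour is compound 3, with no change at the digits printed from compound 2 to compound 3 (within the scatter), and the furthest is compound 1, the gap being a 1.9-fold higher number from compound 1 to compound 2 (0.29 log units; within the scatter). All three measured steps, a 1.9-fold higher number from compound 1 to compound 2 (0.29 log units; within the scatter), a 1.9-fold higher number from compound 1 to compound 3 (0.29 log units; within the scatter) and no change at the digits printed from compound 2 to compound 3 (within the scatter), exchange only the amine on the thiocarbonyl carbon, and none of them moves beyond the scatter. The shared core is the same in every measured compound.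

Compound 4 `O=c1c(CSC(=S)N2CCCC2)coc2ccccc12` differs from compound 2 by hydrogen in place of methoxy on an aromatic carbon. Among the measured compounds shown here, no measured step touches this position, so nothing measured bears directly on the change; the only guidance is that the series as a whole has so far stayed within a narrow band. On that basis compound 4 is expected to stay close to compound 2, the estimated step being a 1.3-fold higher number from compound 2 to compound 4 (0.11 log units; within the scatter), not clearly beyond the scatter. Going by these compounds, the estimate for compound 4 in this assay is 2300 nM, with a range from 900 nM to 6000 nM, the range being wide since the change is untested here.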

Compound 4, half-maximal inhibitory concentration: 3800 nM
Compound 4: middle estimate off by 1.7-fold (0.22 log units), on the low side; low and high end bracket the measured number.
By their numbers in this assay, from the lowest: compounds 1, 2 and 3 (each within the scatter of the next); then compound 4.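

In this assay, hydrogen in place of methoxy on the aromatic carbon gives a 2.1-fold higher number from compound 2 to compound 4 (0.32 log units; beyond the scatter), a modest step but the first in the series to pass beyond the scatter. The earlier compounds shown here all carry methoxy at this place and differ only in the amine on the thiocarbonyl carbon, so they gave no reading of this position; the pair now shows that, with pyrrolidin-1-yl as the amine, the compound with methoxy has the lower number and therefore the stronger inhibition on this read-out. Nothing available accounts for this difference, so the step stands as an observation without an explanation.

The compounds shown leave open whether the same exchange gives a step of similar size with piperidin-1-yl or diisopropylamino as the amine, since both are represented here only with methoxy on the aromatic carbon. They also leave open how other groups at this place compare with methoxy and hydrogen, such as a hydroxyl, a chlorine atom or a longer ethoxy chain, and whether any of these would give a lower number than methoxy.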